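The compounds below may be only part of what the source reports. "The series", "measured", "known", "first", "only" and "open" are said of these compounds alone.

Measured so far:
- compound 1 `COc1ccc(S(=O)(=O)/C=C/c2cccnc2)cc1`: 99.5%
- compound 2 `COc1ccc(S(=O)(=O)/C=C/c2ccc(F)nc2)cc1`: 100%

In an ADME assay on BV-2 cells (Mus musculus) for cytotoxicity, with a stated time of 24 h, tested at 10 uM (on this read-out lower numbers stand for a stronger effect and higher numbers for a weaker effect at the one concentration tested), compound 1 gives 99.5%, and compound 2 gives 100%; the two numbers lie within the scatter of each other, so neither compound can be set apart from the other on this read-out. Within the data shown here, the only step recorded, a number 0.5 percentage points higher from compound 1 to compound 2 (within the scatter), is a fluoro in place of hydrogen on an aromatic carbon and changes nothing beyond the scatter.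

Compound 3 `COc1ccc(S(=O)(=O)/C=C/c2cncnc2)cc1` is not yet measured. It differs from compound 1 by pyrimidin-5-yl in place of pyridin-3-yl on a double-bonded chain carbon bound to a double-bonded chain carbon. Among the measured compounds shown here, no measured step touches the ring itself, so the change from compound 1 to compound 2 is the only guide, and it was flat. Given that both measured compounds sit at the top of the scale, compound 3 is expected to behave alike, with a step of a number 0.5 percentage points lower from compound 1 to compound 3 (within the scatter) that stays within the scatter. The estimate for compound 3 in this assay is 99%, ranging from 90% to 105%.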

Compound 3, a percentage reported as activity, at one concentration (the size of the read-out at that concentration, not a potency): 100%
For compound 3 the middle estimate is 1 percentage points below the measured one, within the range that was stated.
By their numbers in this assay, from the lowest: compounds 1, 2 and 3 (each within the scatter of the next).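

In this assay, the ring itself is now exchanged on a double-bonded chain carbon bound to a double-bonded chain carbon: pyrimidin-5-yl in place of pyridin-3-yl gives a number 0.5 percentage points higher from compound 1 to compound 3 (within the scatter). The earlier step altered only one aromatic carbon of the pyridin-3-yl ring, whereas this one replaces the ring, and the read-out still does not set the two compounds apart. Nothing at hand explains this result.

As far as these compounds go, all three compounds lie within the scatter of each other, so it remains open whether any group at this place can move the read-out. A carboxylic acid or an aminomethyl group on the ring, or a saturated piperidine in place of the aromatic ring, would test this at the same concentration.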